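Bromine on the pendant ring in place of a methoxy

The compounds below may be only part of what the source reports. "The series", "measured", "known", "first", "only" and "open" are said of these compounds alone.

Going by the values given here, the two compounds measured so far share one core and differ only in the pendant aromatic ring. Compound 1 `CC(=O)Nc1cccc(C2CCN(CCCn3c(-c4ccccc4)nc4ccccc43)CC2)c1` carries an unsubstituted phenyl there and gives 2 nM in an assay for displacement of a labelled ligand from melanin-concentrating hormone receptor 1 (Homo sapiens), read by fluorescence; on this read-out higher numbers stand for weaker inhibition and lower numbers for stronger inhibition. Compound 2 `COc1ccccc1-c1nc2ccccc2n1CCCN1CCC(c2cccc(NC(C)=O)c2)CC1` carries a 2-methoxyphenyl and gives 747 nM in this assay, which is the highest of the two numbers, with compound 1 as its nearest neighbour at a far lower number. Among the compounds with values here, the one step that joins them, a 370-fold higher number from compound 1 to compound 2 (2.57 log units; beyond the scatter), is large and well beyond the scatter.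

Compound 3 `CC(=O)Nc1cccc(C2CCN(CCCn3c(-c4ccc(Br)cc4)nc4ccccc43)CC2)c1` is not yet measured. It differs from compound 2 in one place: 4-bromophenyl in place of 2-methoxyphenyl on an aromatic carbon. This change removes the methoxy whose arrival marked the step from compound 1 to compound 2, and adds a bromine elsewhere on the same ring. Nothing measured here shows what a bromine at that position does on its own. Within the data shown here, on the single step available, a large fall in the number is expected from compound 2 to compound 3, a 150-fold lower number from compound 2 to compound 3 (2.17 log units; beyond the scatter). Compound 3 is therefore estimated at 5 nM in this assay, within 1 nM to 40 nM.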

Compound 3, half-maximal inhibitory concentration: 5 nM
The estimate for compound 3 equals the measured number at the digits printed, within the range that was stated.
By their numbers in this assay, from the lowest: compound 1; then compound 3; then compound 2.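

Compound 3 shows that the pendant ring can carry a substituent and keep most of its strength in this assay: the 4-bromophenyl costs only a modest step, a 2.5-fold higher number from compound 1 to compound 3 (0.40 log units; beyond the scatter), so a group on this ring does not by itself bring a large loss, with compound 2 the one case here that shows such a loss. The change from 2-methoxyphenyl to 4-bromophenyl brings back nearly all of the strength lost in compound 2, a 150-fold lower number from compound 2 to compound 3 (2.17 log units; beyond the scatter), yet it swaps the kind of group and its place on the ring in a single step, so the two contributions cannot be separated. No measurement here explains why these two substituted rings behave so differently.

The compounds shown leave open whether the weak result of compound 2 belongs to the methoxy group or to its place on the ring, a question that a 4-methoxyphenyl and a 2-bromophenyl would address directly. Also open, as far as these compounds go, is how this ring responds to other groups at the same place as the bromine, such as an amine or a carboxylic acid.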